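Capping the alcohol of a dibrominated catechol

This account rests on a few compounds, and the source may have more. Where it says the series, first, only, none or still open, it means among the compounds named here.

Compound 1, `CCCOCc1cc(O)c(O)c(Br)c1Br`: 1320 nM
Compound 2, `OCc1cc(O)c(O)c(Br)c1Br`: 20400 nM

In a functional assay on HCT-116 cells (Homo sapiens) for cytotoxicity, read by MTT assay, with a stated time of 96 h (a higher number here means a weaker inhibitor, a lower number a stronger inhibitor), compound 2 gives the higher of the two numbers shown, so it is the weaker inhibitor of the pair. For the measured compounds named here, the single measured step, a 15-fold higher number from compound 1 to compound 2 (1.19 log units; beyond the scatter), is large and separates it from its only neighbour. Compound 3, `COCc1cc(O)c(O)c(Br)c1Br`, differs from compound 2 by methyl in place of hydrogen on an oxygen on a saturated carbon. This change runs in the opposite direction to the measured step, but puts back only a methyl where a propyl had been removed, so it covers part of the same ground. Going by the values given here, the one step that bears on it, a 15-fold higher number from compound 1 to compound 2 (1.19 log units; beyond the scatter), argues for a clearly lower number for compound 3, probably smaller than that whole step. The expectation for compound 3 is therefore a 4.1-fold lower number from compound 2 to compound 3 (0.61 log units; beyond the scatter), giving an estimated 5000 nM with a range from 1500 nM to 15000 nM.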

Compound 3, half-maximal inhibitory concentration: 14100 nM
The estimate for compound 3 lay 2.8-fold (0.45 log units) below the measured number; measured number inside the range.
By their numbers in this assay, from the lowest: compound 1; then compounds 3 and 2 (each within the scatter of the next).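

In this assay, capping the hydroxymethyl as methoxymethyl leaves the two compounds indistinguishable (a 1.4-fold lower number from compound 2 to compound 3 (0.16 log units; within the scatter)), so a methyl on this oxygen is not enough to separate compound 3 from the free alcohol. The gap to the propyl ether remains large (an 11-fold higher number from compound 1 to compound 3 (1.03 log units; beyond the scatter)), which shows that capping the oxygen does not by itself account for the result with compound 1; among these three compounds, only the propyl group stands apart. Nothing measured here explains why propyl and methyl differ in this way.

Ethyl, butyl and longer chains on this oxygen remain open, so it is unclear how the number changes as the chain grows, or whether it keeps falling beyond propyl. On these data alone, a chain ending in an amine or a carboxylic acid is equally open.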